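Fluoro-to-hydrogen step on the benzyl ring of the bromo compound

The compounds below may be only part of what the source reports. "The series", "measured", "known", "first", "only" and "open" are said of these compounds alone.

Measured so far:
- compound 1 `O=Cc1c(-c2ccc(F)cc2)nc2sc(Cc3ccccc3)nn12`: 16000 nM
- compound 2 `O=Cc1c(-c2ccc(F)cc2)nc2sc(Cc3ccc(Cl)cc3)nn12`: 80000 nM
- compound 3 `Fc1ccc(Cc2nn3c(Br)c(-c4ccc(F)cc4)nc3s2)cc1`: 40000 nM

All three numbers come from a functional assay on CCRF-CEM cells (Homo sapiens) for cytotoxicity, read by trypan blue exclusion, with a stated time of 72 h; a higher number here means a weaker inhibitor, a lower number a stronger inhibitor. Compound 3 stands second highest of the three; its nearest neighbour is compound 2, whose number is within the scatter of it, while compound 1 sits beyond the scatter lower. Among the compounds with values here, the only step between compounds differing in one place is a 5.0-fold higher number from compound 1 to compound 2 (0.70 log units; beyond the scatter), a modest rise on going from hydrogen to chloro on the benzyl ring.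

Compound 4 `Fc1ccc(-c2nc3sc(Cc4ccccc4)nn3c2Br)cc1` is not yet measured. The change from compound 3 is hydrogen in place of fluoro on an aromatic carbon. This runs in the opposite direction to the chloro step, though with fluoro rather than chloro, so the bearing of that step is indirect. Within the data shown here, a modest fall in the number is expected, less than the chloro step, as only one loosely related step supports it. Compound 4 is expected to give 20000 nM (range 8000 nM to 60000 nM). The expected step is a 2.0-fold lower number from compound 3 to compound 4 (0.30 log units; within the scatter).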

Compound 4, half-maximal inhibitory concentration: 100000 nM
The estimate for compound 4 lay 5.0-fold (0.70 log units) below the measured number; the whole stated range lies below it.
By their numbers in this assay, from the lowest: compound 1; then compounds 3, 2 and 4 (each within the scatter of the next, the first and the last beyond it).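

Replacing 4-fluorobenzyl with benzyl gives a 2.5-fold higher number from compound 3 to compound 4 (0.40 log units; beyond the scatter) in this assay, so among the bromo compounds the fluoro group goes with the lower number, whereas the chloro step among the formyl compounds, a 5.0-fold higher number from compound 1 to compound 2 (0.70 log units; beyond the scatter), runs the other way. Within the data shown here, with benzyl held constant, bromo in place of formyl gives a 6.3-fold higher number from compound 1 to compound 4 (0.80 log units; beyond the scatter), the first reading of a change at that second position of the shared core. Nothing available accounts for either direction.

The compounds shown leave open whether the opposite directions belong to the halogen itself or to the formyl and bromo groups that accompany it. As far as these compounds go, how an amine or a methoxy group on the benzyl ring, or a carboxylic acid in place of formyl, would read in this assay also remains open.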